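A few compounds are considered here, and "the series" means these few. Any claim that something is new, unique, unknown or untested is made for them only; others in the source may bear on it.

Within the data shown here, compound 2 `Cc1c(C)c2c(c(C)c1OCc1ccccc1)CCC(C)(COc1ccc(/C=C3\SC(=O)NC3=O)cc1)O2` gives the higher of the two numbers so far in an in vivo ADME assay on the whole organism for pharmacokinetics, with Rattus norvegicus as the target, at a dose of 100 mg/kg by the oral route (on this read-out higher numbers stand for a longer-lived compound and lower numbers for a shorter-lived compound), where it reaches 10.4 h. Among the measured compounds shown here, its nearest neighbour is compound 1 `Cc1c(C)c2c(c(C)c1O)CCC(C)(COc1ccc(/C=C3\SC(=O)NC3=O)cc1)O2`, which in this assay gives 2.82 h; the step of a 3.7-fold higher number from compound 1 to compound 2 (0.57 log units; beyond the scatter) is the only measured step in the set, and it concerns a benzyl in place of hydrogen on an oxygen on an aromatic ring.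

Compound 3 `Cc1c(C)c2c(c(C)c1OCc1ccccc1)CCC(C)(COc1ccc(CC3SC(=O)NC3=O)cc1)O2` has not yet been measured. It differs from compound 2 in a different part of the molecule: a group of 8 heavy atoms (4 carbon, 1 nitrogen, 2 oxygen, 1 sulfur; one five-membered non-aromatic ring with 2 hetero atoms) in place of a group of 8 heavy atoms (4 carbon, 1 nitrogen, 2 oxygen, 1 sulfur; one five-membered non-aromatic ring with 2 hetero atoms), on an aromatic carbon. For the measured compounds named here, the one measured step, from compound 1 to compound 2, touches the other end of the shared core and so says nothing direct about this change. Going by the values given here, no measured step bears on the change from compound 2 to compound 3, so the expectation for compound 3 in this assay rests only on the number of compound 2 and is therefore a step of about none beyond the scatter, a 1.2-fold lower number from compound 2 to compound 3 (0.06 log units; within the scatter), with a wide range on either side. Compound 3 is thus estimated at 9 h, between 3.5 h and 25 h.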

Compound 3, half-life: 9.27 h
Compound 3: middle estimate off by 1.0-fold (0.01 log units), on the low side; the range from low to high includes it.
By their numbers in this assay, from the lowest: compound 1; then compounds 3 and 2 (each within the scatter of the next).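

Among these compounds, at the aromatic carbon para to a large group, the first change to be read in this assay replaces a group with 3 double bonds outside aromatic rings by (2,4-dioxo-1,3-thiazolidin-5-yl)methyl, with 2 such bonds and the same count of heavy atoms, and it gives (a 1.1-fold lower number from compound 2 to compound 3 (0.05 log units; within the scatter)). Among the compounds shown here, this read-out therefore does not separate the two groups in the setting of compound 2 and compound 3, whereas the only earlier step, at the other end of the shared core, lay beyond the scatter (a 3.7-fold higher number from compound 1 to compound 2 (0.57 log units; beyond the scatter)). No measurement shown here offers an explanation for this result.

The compounds shown leave open whether the same exchange would also make no difference beyond the scatter with hydrogen in place of benzyl on the oxygen, as in compound 1. They also leave open how the half-life would respond if a carboxylic acid or a longer chain carrying an amine stood in place of (2,4-dioxo-1,3-thiazolidin-5-yl)methyl on the same aromatic carbon.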